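Fluorine on the Pendant Phenyl: What Compound 4 Might Give

A few compounds are considered here, and "the series" means these few. Any claim that something is new, unique, unknown or untested is made for them only; others in the source may bear on it.

Measured so far in a functional assay on HL-60 cells (Homo sapiens) for inhibition, read by MTT assay, with a stated time of 72 h; on this read-out lower numbers stand for stronger inhibition and higher numbers for weaker inhibition:
compound 1 `COc1cc(OC)cc(N2CCN(C(=O)c3onc(C)c3-c3ccccc3)CC2)c1` gives 152 nM;
compound 2 `COc1cccc(N2CCN(C(=O)c3oc(C)nc3-c3ccc(F)cc3)CC2)c1` gives 112 nM;
compound 3 `COc1cccc(N2CCN(C(=O)c3oc(C)nc3-c3ccccc3)CC2)c1` gives 34.8 nM.

Compound 1 and compound 3 have different cores, and the difference between the two cores is not broken down here. From compound 3 to compound 2 the change is fluoro in place of hydrogen on an aromatic carbon, and this step was a 3.2-fold higher number from compound 3 to compound 2 (0.51 log units; beyond the scatter). Compound 4 `COc1cc(OC)cc(N2CCN(C(=O)c3onc(C)c3-c3cccc(F)c3)CC2)c1` is the unmeasured one: its change from compound 1 is fluoro in place of hydrogen on an aromatic carbon. This is the same kind of change, but not the same: in compound 2 the fluoro sits para to a large group, in compound 4 meta to a large group, and the cores differ. Among the compounds with values here, for compound 4 the expected step is a 2.1-fold higher number from compound 1 to compound 4 (0.32 log units; beyond the scatter), a weakening resting on the one earlier step. Compound 4 is thus estimated at 320 nM, between 120 nM and 900 nM.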

Compound 4, half-maximal inhibitory concentration: 152 nM
For compound 4 the middle estimate is 2.1-fold (0.32 log units) above the measured one; the measured number falls inside the stated range.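

In this assay the phenyl to 3-fluorophenyl change gives no change at the digits printed from compound 1 to compound 4 (within the scatter) and so does not repeat the weakening seen in the earlier pair. Set side by side, the two steps disagree: the same change on two cores in this assay, a 3.2-fold higher number (0.51 log units; beyond the scatter) from compound 3 to compound 2 and no change at the digits printed (within the scatter) from compound 1 to compound 4, 3.2-fold (0.51 log units) apart, beyond the scatter of two such steps. This shows that the effect of fluoro in place of hydrogen cannot simply be copied from one core to another in this series, but it does not show why, as the two pairs differ both in core and in where the fluoro sits on the phenyl ring, and the data do not separate these two differences.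

The compounds shown leave open whether fluoro at one matching ring position would behave alike on both cores. They also leave open whether a different group there, such as chloro or nitrile, would follow either step.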